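A Bromohydroxyphenyl Enone Follows a Thienyl Analogue

The source may hold more compounds than are shown below. What is called first, only, known or untested is meant among the compounds shown, and "the series" means these compounds.

Compound 1: `COc1ccc(C(=O)/C=C/c2ccc(N3CCCC3)cc2)c2c1C=CC(C)(C)O2` — 4740 nM
Compound 2: `COc1ccc(C(=O)/C=C/c2ccsc2)c2c1C=CC(C)(C)O2` — > 10000 nM

In a functional assay on HepG2 cells (Homo sapiens) for antiproliferative activity, read by MTT assay, with a stated time of 24 h (a higher number here means a weaker inhibitor, a lower number a stronger inhibitor), compound 1 gives 4740 nM. Compound 2 yields only a limit, > 10000 nM, so it sits at the limit of > 10000 nM in this assay, at which 1 of the 2 values shown sits, and stands as the weaker of the two shown values. The not yet measured compound 3 `COc1ccc(C(=O)/C=C/c2ccc(O)c(Br)c2)c2c1C=CC(C)(C)O2` differs from compound 2 by 3-bromo-4-hydroxyphenyl in place of thiophen-3-yl on a double-bonded chain carbon bound to a double-bonded chain carbon. For the measured compounds named here, no step between measured compounds is known, so the step of an at least 1.6-fold lower number from compound 2 to compound 3 (0.22 log units; that floor lies within the scatter) is an expectation only; a move toward stronger inhibition, beyond the scatter, is expected, though a second limit cannot be excluded. Compound 3 is estimated at 6000 nM, in the range 2000 nM to 20000 nM.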

Compound 3, half-maximal inhibitory concentration: > 10000 nM
Compound 3 ended at the assay's limit; the forecaster's own chance of this, stated with the estimate: 35%; middle value at least 1.6-fold (0.22 log units) away from the limit.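

Compound 2 and compound 3 both give only a limit, so no step between them can be read: the limit of > 10000 nM in this assay, at which 2 of the 3 values shown sit.

The compounds shown leave open whether thiophen-3-yl or 3-bromo-4-hydroxyphenyl goes with the stronger inhibition.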